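The source may hold more compounds than are shown below. What is called first, only, known or untested is meant among the compounds shown, and "the series" means these compounds.

In a functional assay on SK-BR-3 cells (Homo sapiens) for antiproliferative activity (a higher number here means a weaker inhibitor, a lower number a stronger inhibitor), compound 1 `CC(C)=CCc1cc(C(=O)Nc2cc3ccc(OCCCN(C(C)C)C(C)C)c(C)c3oc2=O)ccc1O` gives 1600 nM and compound 2 `CC(C)=CCc1cc(C(=O)Nc2cc3ccc(OCCCNC(C)(C)C)c(C)c3oc2=O)ccc1O` gives 660 nM while compound 3 `CC(C)=CCc1cc(C(=O)Nc2cc3ccc(OCCCN(C)C(C)(C)C)c(C)c3oc2=O)ccc1O` gives 880 nM and lies within the scatter of both. Compound 4 `CC(C)=CCc1cc(C(=O)Nc2cc3ccc(OCCCNCC(=O)O)c(C)c3oc2=O)ccc1O` carries the change (carboxymethyl)amino in place of methyl(tert-butyl)amino on a saturated chain carbon, three bonds along the chain from an oxygen on an aromatic ring on the same saturated chain carbon, three bonds along the chain from an oxygen on an aromatic ring. The measured guides are a 2.4-fold lower number from compound 1 to compound 2 (0.38 log units; beyond the scatter) and a 1.8-fold lower number from compound 1 to compound 3 (0.26 log units; within the scatter) and a 1.3-fold higher number from compound 2 to compound 3 (0.12 log units; within the scatter) and all three are small. None of them brings in a carboxymethyl group, so they bear on this change only loosely. A higher number in this assay is expected on judgement, with wide uncertainty. The expected step is a 2.8-fold higher number from compound 3 to compound 4 (0.45 log units; beyond the scatter) and no more than that. For compound 4 the estimated value is 2500 nM with an expected range from 700 nM to 10000 nM for now.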

Compound 4, half-maximal inhibitory concentration: 7570 nM
Estimate against measurement, compound 4: 3.0-fold (0.48 log units) below, within the range that was stated.
By their numbers in this assay, from the lowest: compounds 2, 3 and 1 (each within the scatter of the next, the first and the last beyond it); then compound 4.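

On the saturated chain carbon, three bonds along the chain from an oxygen on an aromatic ring, carboxymethyl on the amine raises the number in this assay further than any change among the alkyl amines: an 8.6-fold higher number from compound 3 to compound 4 (0.93 log units; beyond the scatter) and an 11-fold higher number from compound 2 to compound 4 (1.06 log units; beyond the scatter) and a 4.7-fold higher number from compound 1 to compound 4 (0.67 log units; beyond the scatter). Compound 4 therefore stands beyond the scatter of all three alkyl amines, so this position does respond to the amine substituent. No measurement here bears on the cause of this shift.

From the compounds shown here alone, whether the shift follows the free carboxylic acid or the loss of the bulky alkyl groups remains open. The methyl ester of compound 4 or a 2-hydroxyethyl group on the same amine nitrogen would separate the two.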